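The compounds below may be only part of what the source reports. "The series", "measured", "known", "first", "only" and "open" are said of these compounds alone.

Of the compounds shown here, three built on one shared core have been measured in a functional assay on PC-3 cells (Homo sapiens) for antiproliferative activity, read by MTT assay, with a stated time of 72 h; a higher number here means a weaker inhibitor, a lower number a stronger inhibitor. Compound 1 `COc1cc2ncnc(N3CCCc4ccccc43)c2cc1NC(=O)C=C(C)C` gives 6130 nM in this assay. Compound 2 `CC(C)=CC(=O)Nc1cc2c(N3CCCc4ccccc43)ncnc2cc1O[C@@H]1CCOC1` gives 9020 nM, and compound 3 `CC(C)/C=C/C(=O)Nc1cc2c(N3CCCc4ccccc43)ncnc2cc1O[C@@H]1CCOC1` gives 8510 nM. Compound 1 sits at the low end of these three numbers, but its gaps to compound 3 and to compound 2 both fall within the scatter, so no ordering among the three can be claimed from these numbers.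

Compound 4 `COc1cc2ncnc(N3CCCc4ccccc43)c2cc1NC(=O)/C=C/CN(C)C` differs from compound 1 in one place: 3-(dimethylamino)prop-1-en-1-yl in place of 2-methylprop-1-en-1-yl on a carbonyl carbon. Of the measured steps, the one that bears most directly on this change is the earlier exchange at the same carbonyl carbon, which gave a 1.1-fold lower number from compound 2 to compound 3 (0.03 log units; within the scatter). The other step, an exchange on the ring oxygen, gave a 1.5-fold higher number from compound 1 to compound 2 (0.17 log units; within the scatter). Neither exchange moved the number beyond the scatter. The change to compound 4 is larger than either of those, and nothing measured here shows a group of this kind at this place, so the estimate rests on the small size of the steps seen so far. The expected step is a 1.5-fold lower number from compound 1 to compound 4 (0.19 log units; within the scatter), with wide uncertainty. Compound 4 is estimated at 4000 nM, within a range from 1000 nM to 15000 nM.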

Compound 4, half-maximal inhibitory concentration: 1750 nM
Estimate against measurement, compound 4: 2.3-fold (0.36 log units) above; the measured number falls inside the stated range.
By their numbers in this assay, from the lowest: compound 4; then compounds 1, 3 and 2 (each within the scatter of the next).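

In this assay, among the compounds shown here, putting 3-(dimethylamino)prop-1-en-1-yl in place of 2-methylprop-1-en-1-yl on the carbonyl carbon gives a 3.5-fold lower number from compound 1 to compound 4 (0.54 log units; beyond the scatter) and is the first step in this set to go beyond the scatter. The earlier exchange on this same carbonyl carbon, from one all-carbon group to another, stayed within the scatter at a 1.1-fold lower number from compound 2 to compound 3 (0.03 log units; within the scatter) and gave no sign that the number could move, so this position is now seen to respond to at least one change. The entering group has more heavy atoms than the one it replaces and, unlike it, contains a nitrogen, but no measurement here explains why the number fell.

The compounds shown leave open whether the nitrogen or the longer chain matters, a question that an all-carbon chain of the same length could help to answer, while piperidine or morpholine in place of the dimethylamino group would test how much the amine itself can vary. They also leave open whether 3-(dimethylamino)prop-1-en-1-yl has a similar effect when oxolan-3-yl replaces methyl on the ring oxygen.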